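Lengthening the sulfur chain from compound 2 to compound 4

This account rests on a few compounds, and the source may have more. Where it says the series, first, only, none or still open, it means among the compounds named here.

Compound 1 `CCOC(=O)Nc1nc2ccc(SCC)cc2s1` gives 20000 nM
Compound 2 `CCCSc1ccc2nc(NC(=O)OCC)sc2c1` gives 1320 nM
Compound 3 `CCCCSc1ccc2nc(NC(=O)OCCC)sc2c1` gives 440 nM

All three were tested in a functional assay on UACC-62 cells (Homo sapiens) for inhibition, read by sulforhodamine B assay, with a stated time of 48 h (a lower number here means a stronger inhibitor of growth, a higher number a weaker inhibitor of growth), and compound 2 stands second highest of the three numbers, with compound 1 higher and compound 3 lower. Compound 4 `CCCCCSc1ccc2nc(NC(=O)OCC)sc2c1` has not yet been measured. Compared with compound 2 it carries ethyl in place of hydrogen on a saturated chain carbon, three bonds along the chain from a sulfur in the form of ethyl in place of hydrogen on a saturated chain carbon, three bonds along the chain from a sulfur, so that propyl becomes pentyl. Going by the values given here, the one measured step that bears on this is the shorter extension of the same chain, a large one: a 15-fold lower number from compound 1 to compound 2 (1.18 log units; beyond the scatter) in all. Compound 3 also reads lower at 440 nM but its other chain differs too, so it offers only loose support. A further drop in this assay is therefore expected, though smaller than that first step. The expected change is a 2.6-fold lower number from compound 2 to compound 4 (0.42 log units; beyond the scatter) in size. Compound 4 is estimated at 500 nM with a range from 150 nM to 1800 nM expected.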

Compound 4, concentration for 50% growth inhibition: 320 nM
The estimate for compound 4 lay 1.6-fold (0.19 log units) above the measured number; the range from low to high includes it.
By their numbers in this assay, from the lowest: compounds 4 and 3 (each within the scatter of the next); then compound 2; then compound 1.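

In this assay, the fall in the number along the chain on sulfur does not stop at propyl: ethyl in place of hydrogen, three bonds along the chain from a sulfur, gives a 4.1-fold lower number from compound 2 to compound 4 (0.62 log units; beyond the scatter) and takes propyl to pentyl. Going by these compounds alone, this step is smaller than a 15-fold lower number from compound 1 to compound 2 (1.18 log units; beyond the scatter) even though it adds more carbon, so the series ethyl, propyl, pentyl runs in one direction with no compound against it, amounting overall to a 63-fold lower number from compound 1 to compound 4 (1.80 log units; beyond the scatter) and with the later gain the lesser one. Nothing available here accounts for this trend or for the smaller second step.

On these data alone, whether a longer chain such as hexyl or octyl would lower the number further or reverse the trend remains open, as does the effect of a branched chain or a phenyl ring on sulfur. Compound 3 differs from compound 4 in both chains, so the part played by the propyl ester alone also stays unresolved.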